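Urea to amide in a cysteinyl leukotriene antagonist series

The source may hold more compounds than are shown below. What is called first, only, known or untested is meant among the compounds shown, and "the series" means these compounds.

Of the compounds shown here, two sharing one core have been measured in an assay on isolated protein (Cavia porcellus) with cysteinyl leukotriene receptor (Homo sapiens) as the target; on this read-out higher numbers stand for higher potency (the scale is a negative logarithm) and lower numbers for lower potency. Compound 1 `COc1cc(C(=O)NS(=O)(=O)c2ccccc2)ccc1Cc1cn(C2CCCC2)c2ccc(NC(=O)OC3CCCC3)cc12` gives 7.84 in this assay. Compound 2 `COc1cc(C(=O)NS(=O)(=O)c2ccccc2C)ccc1Cc1cn(C)c2ccc(NC(=O)NC3CCCC3)cc12` gives 9.31 in this assay, the higher of the two numbers, standing above compound 1 by a gap that is beyond the scatter. Going by the values given here, compound 1 and compound 2 differ in more than one place, so no single step between them can be set out; only their two values are known.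

Compound 3 `COc1cc(C(=O)NS(=O)(=O)c2ccccc2C)ccc1Cc1cn(C)c2ccc(NC(=O)CC3CCCC3)cc12` is the next compound and has not yet been measured in this assay. It differs from compound 2 in one place: cyclopentylmethyl in place of cyclopentylamino on a carbonyl carbon. Among the compounds with values here, no comparable step between measured compounds is available to anchor the expectation, so the account rests on compound 2 alone. A modest fall in this assay is expected, with the step from compound 2 to compound 3 estimated at a number 0.51 log units lower from compound 2 to compound 3 (beyond the scatter). For compound 3 the expected value in this assay is 8.8, within a range from 8 to 9.5.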

Compound 3, negative logarithm of the antagonist equilibrium constant: 9.64
Beside the measured number, compound 3's estimate is 0.84 log units below it; measured number outside the range, above it.
By their numbers in this assay, from the lowest: compound 1; then compound 2; then compound 3.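

In this assay, putting cyclopentylmethyl in place of cyclopentylamino on a carbonyl carbon gives a number 0.33 log units higher from compound 2 to compound 3 (beyond the scatter) and so costs no potency, although the entering group has no hydrogen-bond donor and the leaving group has one. For this pair, then, a high number at this position does not depend on that donor, and compound 3 holds 9.64 with a group built of carbon only. Nothing among the data presented accounts for the rise.

The compounds shown do not tell whether the rise depends on the distance from the carbonyl carbon to the ring, as a cyclopentylethyl group would test, or on the ring itself, as a cyclohexylmethyl group or an open-chain pentyl group would test. As far as these compounds go, compound 1 cannot settle this, as it differs from compound 2 and compound 3 in more than one place, and whether the rise would carry over to other substituents elsewhere on the shared core also remains open.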